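The source may report more compounds than this note shows. Statements on the series, on what has been measured and on what is new or still open speak of the compounds shown alone.

Measured in a functional assay on COLO 205 cells (Homo sapiens) for cytotoxicity, read by MTT assay, with a stated time of 24 h; on this read-out lower numbers stand for stronger inhibition and higher numbers for weaker inhibition:
compound 1, `COc1ccc(/C=C\C(=O)O)c(OCc2cn(-c3ccc(NC(C)=O)cc3)nn2)c1CC=C(C)C`: 22600 nM
compound 2, `COc1ccc(/C=C\C(=O)O)c(OCc2cn(-c3nc4ccccc4s3)nn2)c1CC=C(C)C`: 20200 nM

Both measured compounds share one core and differ only in the group on the aromatic nitrogen of the triazole. Within the data shown here, the single measured step, a 1.1-fold lower number from compound 1 to compound 2 (0.05 log units; within the scatter), shows that this exchange left the read-out essentially unchanged, so compound 2 and compound 1 sit within the scatter of each other and neither can be called the more active of the two.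

Compound 3, `COc1ccc(/C=C\C(=O)O)c(OCc2cn(-c3cccc([N+](=O)[O-])c3)nn2)c1CC=C(C)C`, is not yet measured in this assay. It differs from compound 2 in the same position: 3-nitrophenyl in place of 1,3-benzothiazol-2-yl on an aromatic nitrogen. Among the measured compounds shown here, the only step that bears on this change is the one from compound 1 to compound 2, which varied the same substituent on the same aromatic nitrogen and stayed within the scatter. With one such comparison available, the expectation is for no step beyond the scatter, and the estimated change is a 1.0-fold higher number from compound 2 to compound 3 (0.02 log units; within the scatter).

On that basis compound 3 is expected to give about 21000 nM in this assay, with a likely range from 8000 nM to 55000 nM.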

Compound 3, half-maximal inhibitory concentration: 6900 nM
Estimate against measurement, compound 3: 3.0-fold (0.48 log units) above; the measured number lies below the stated range.
By their numbers in this assay, from the lowest: compound 3; then compounds 2 and 1 (each within the scatter of the next).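

In this assay the group on the aromatic nitrogen is not neutral after all: a 1.1-fold lower number from compound 1 to compound 2 (0.05 log units; within the scatter) had left the read-out flat, but 3-nitrophenyl in place of 1,3-benzothiazol-2-yl gives a 2.9-fold lower number from compound 2 to compound 3 (0.47 log units; beyond the scatter), and 3-nitrophenyl in place of 4-acetamidophenyl gives a 3.3-fold lower number from compound 1 to compound 3 (0.52 log units; beyond the scatter), both modest steps. The exchange between 1,3-benzothiazol-2-yl and 3-nitrophenyl keeps the same counts of heavy atoms, hydrogen-bond donors and hydrogen-bond acceptors, with no net charge on either side, so these counts do not separate the two groups; what differs is a single six-membered aromatic ring carrying a nitro group against a fused pair of aromatic rings holding sulfur. Nothing available accounts for the step, and the read-out alone offers no explanation of it.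

Still open, going by these compounds, is whether the lower number belongs to the nitro group itself, which a plain phenyl, or an amine or a nitrile in place of the nitro group, would help to settle. Also open, on these data alone, is whether the step holds when the carboxylic acid of the shared core is replaced by an ester or an amide.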